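Methyl in place of chloro: a clearance forecast

A few compounds are considered here, and "the series" means these few. Any claim that something is new, unique, unknown or untested is made for them only; others in the source may bear on it.

Of the compounds shown here, three that share one core have been measured in an in vitro ADME assay on microsomes from liver (Homo sapiens) for pharmacokinetics, read by LC-MS, with a stated time of 10 min, tested at 1 uM; on this read-out lower numbers stand for slow clearance and higher numbers for fast clearance. Compound 1 `CN1C[C@H](C(=O)Nc2ccc(C(F)(F)F)cc2)[C@@H](c2ccc(/C=C/C(=O)Nc3ccccc3N)cc2)C1` gives 6 mL/min/kg, compound 2 `CN1C[C@H](C(=O)Nc2cccc(F)c2)[C@@H](c2ccc(/C=C/C(=O)Nc3ccccc3N)cc2)C1` gives 6 mL/min/kg, and compound 3 `CN1C[C@H](C(=O)Nc2cccc(Cl)c2)[C@@H](c2ccc(/C=C/C(=O)Nc3ccccc3N)cc2)C1` gives 7 mL/min/kg. Compound 3 thus stands level with the other two, and its gaps to both lie within the usual scatter of repeated measurements.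

Compound 4 `Cc1cccc(NC(=O)[C@H]2CN(C)C[C@@H]2c2ccc(/C=C/C(=O)Nc3ccccc3N)cc2)c1` departs from compound 3 in a single place: methyl in place of chloro on an aromatic carbon. Methyl takes the place of chloro on an aromatic carbon, meta to a large group.

The closest measured comparison is a 1.2-fold higher number from compound 2 to compound 3 (0.07 log units; within the scatter), where chloro replaces fluoro on an aromatic carbon. Two larger swaps of the whole aromatic group on the amide nitrogen are no change at the digits printed from compound 1 to compound 2 (within the scatter) and a 1.2-fold higher number from compound 1 to compound 3 (0.07 log units; within the scatter). All three steps stay within the scatter. None of them involves a methyl, so they offer only indirect guidance, and they point to no direction. In this assay, no step beyond the scatter is therefore expected, and the estimated change is no change at the digits printed from compound 3 to compound 4 (within the scatter). For compound 4, the expected clearance is 7 mL/min/kg, with an estimated range from 4 mL/min/kg to 12 mL/min/kg.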

Compound 4, clearance: 14 mL/min/kg
Beside the measured number, compound 4's estimate is 2.0-fold (0.30 log units) below it; the whole stated range lies below it.
By their numbers in this assay, from the lowest: compounds 1, 2, 3 and 4 (each within the scatter of the next, the first and the last beyond it).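

In this assay, methyl in place of chloro on this aromatic carbon, meta to a large group, gives a 2.0-fold higher number from compound 3 to compound 4 (0.30 log units; within the scatter), so this single swap on its own stays within the scatter. For the compounds shown here, compound 4 nevertheless brings the first steps that pass beyond the scatter: methyl in place of fluoro at the same place gives a 2.3-fold higher number from compound 2 to compound 4 (0.37 log units; beyond the scatter), and 3-methylphenyl in place of 4-(trifluoromethyl)phenyl gives a 2.3-fold higher number from compound 1 to compound 4 (0.37 log units; beyond the scatter), both of them modest, so the group on the amide nitrogen can make a small difference to this read-out after all, which the first three compounds did not show. Nothing available here bears on what lies behind these steps.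

The compounds shown leave open whether this separation from the fluoro compound belongs to methyl alone or would also appear with another group on the same aromatic carbon, such as an ethyl, a methoxy or a hydroxymethyl group. They also leave open where a plain phenyl group, with only hydrogen at this place, would fall among these four compounds.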